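Replacing 4-methoxyphenyl with 2-chloropyridin-3-yl: working notes

The source may hold more compounds than are shown below. What is called first, only, known or untested is meant among the compounds shown, and "the series" means these compounds.

Measured so far in a functional assay on A549 cells (Homo sapiens) for cytotoxicity, read by MTT assay, with a stated time of 24 h; on this read-out higher numbers stand for weaker inhibition and lower numbers for stronger inhibition:
- compound 1 `COc1ccc(/C=C\C(=O)O)c(OCc2cn(-c3cccc(C#N)c3)nn2)c1CC=C(C)C`: "not determined" (no result reported)
- compound 2 `COc1ccc(-n2cc(COc3c(/C=C\C(=O)O)ccc(OC)c3CC=C(C)C)nn2)cc1`: 10200 nM

Among the measured compounds shown here, compound 2, at 10200 nM, carries the only number, so it cannot yet be ranked against anything. Compound 1 offers no result for comparison.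

Compound 3 `COc1ccc(/C=C\C(=O)O)c(OCc2cn(-c3cccnc3Cl)nn2)c1CC=C(C)C` is still to be measured in this assay. It keeps the shared core of compound 2 and changes one group: 2-chloropyridin-3-yl in place of 4-methoxyphenyl on an aromatic nitrogen. In words, 2-chloropyridin-3-yl stands in place of 4-methoxyphenyl on an aromatic nitrogen of a five-membered aromatic ring with 3 nitrogen.

For the measured compounds named here, the series holds no step between measured compounds, so the data give no size for a change at this place. No step beyond the scatter is therefore expected, and neither direction is favoured. The estimated change is a 1.1-fold higher number from compound 2 to compound 3 (0.03 log units; within the scatter), anchored only on compound 2 at 10200 nM. For compound 3 the estimated value is 11000 nM, with an expected range from 4000 nM to 30000 nM.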

Compound 3, half-maximal inhibitory concentration: 5600 nM
Compound 3: middle estimate off by 2.0-fold (0.29 log units), on the high side; low and high end bracket the measured number.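

In this assay, this place now has its first readable step, a 1.8-fold lower number from compound 2 to compound 3 (0.26 log units; within the scatter), so the data do not separate 2-chloropyridin-3-yl from 4-methoxyphenyl on an aromatic nitrogen of the five-membered aromatic ring with 3 nitrogen. Within this read-out, a six-membered aromatic ring of carbon only and a six-membered aromatic ring with 1 hetero atom are therefore both accommodated at this place, and the exchange of these two groups gives no sign of a step beyond the scatter. Among the compounds shown here, no measurement bears on the reason for this result, and the single step cannot show which features of either group matter here.

Steps involving compound 1 cannot be read, so the nitrile-bearing ring of that compound adds nothing to the comparison at this place. The compounds shown leave open whether an aromatic ring carrying an amine or a carboxylic acid on the same aromatic nitrogen, or a simple longer alkyl chain there instead of a ring, would produce a step beyond the scatter in this assay.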